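Swapping Methyl for Two Methoxy Groups on a Urea

The compounds below may be only part of what the source reports. "The series", "measured", "known", "first", "only" and "open" are said of these compounds alone.

Compound 1 `O=C(Nc1ccccc1Cl)Nc1nn(-c2ccccc2)c(=O)c2ccccc12` gives 49%
Compound 2 `O=C(Nc1ccc(Cl)cc1)Nc1nn(-c2ccccc2)c(=O)c2ccccc12` gives 13%
Compound 3 `Cc1ccc(NC(=O)Nc2nn(-c3ccccc3)c(=O)c3ccccc23)cc1` gives 45%

All three measured compounds were tested in an assay on CHO cells for displacement of a labelled ligand from adenosine receptor A3 (Homo sapiens), tested at 1 uM; on this read-out lower numbers stand for less inhibition and higher numbers for more inhibition at the one concentration tested (going by the name of the read-out). Compound 3 stands second highest of the three numbers; it lies near compound 1, since the step of a number 4 percentage points lower from compound 1 to compound 3 (within the scatter) is within the scatter, and far from compound 2, since the step of a number 32 percentage points higher from compound 2 to compound 3 (beyond the scatter) is large. The other large step, a number 36 percentage points lower from compound 1 to compound 2 (beyond the scatter), shows that moving a chloro group on this phenyl ring can also change the read-out strongly.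

The next compound, compound 4 `COc1ccc(NC(=O)Nc2nn(-c3ccccc3)c(=O)c3ccccc23)c(OC)c1`, is still to be measured in this assay. It differs from compound 3 by 2,4-dimethoxyphenyl in place of 4-methylphenyl on an amide-type nitrogen.

For the measured compounds named here, no measured step swaps a methyl for a methoxy group, so the measured steps only set the range: the same phenyl ring has given numbers from the level of compound 2 up to that of compound 1. A modest downward step, a number 10 percentage points lower from compound 3 to compound 4 (within the scatter), is therefore expected, with wide uncertainty. Compound 4 is estimated to give 35% in this assay, between 10% and 60%.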

Compound 4, a percentage reported as inhibition, at one concentration (the size of the read-out at that concentration, not a potency): 33%
Compound 4: the middle estimate sits 2 percentage points above what was measured, and the stated range covers the measured number.
By their numbers in this assay, from the lowest: compound 2; then compound 4; then compounds 3 and 1 (each within the scatter of the next).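

Putting 2,4-dimethoxyphenyl on this amide-type nitrogen in this assay gives a number 12 percentage points lower from compound 3 to compound 4 (beyond the scatter) and a number 16 percentage points lower from compound 1 to compound 4 (beyond the scatter) but also a number 20 percentage points higher from compound 2 to compound 4 (beyond the scatter) and so places compound 4 in the middle of the set. This position therefore does not only give numbers near the level of compounds 1 and 3 or near that of compound 2: a ring with two methoxy groups, counted with two hydrogen-bond acceptors where 4-methylphenyl has none, lands at a level of its own. No separate measurement is available to explain this result.

As far as these compounds go, the two methoxy groups appear only together here, so what a single methoxy group would do on this phenyl ring, and which of the pair matters more, stays open. Also open, from the compounds shown here alone, is how the read-out would respond to a phenyl ring carrying an amine or a carboxylic acid on this nitrogen, or to a longer chain in place of the ring.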